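Saturating the indene double bond in a dopamine-type antagonist

A few compounds are considered here, and "the series" means these few. Any claim that something is new, unique, unknown or untested is made for them only; others in the source may bear on it.

Measured so far in a functional assay on the whole organism for antagonist activity, with Rattus norvegicus as the target; a lower number here means that less compound is needed, a higher number that more compound is needed for the effect:
compound 1, `C1=C(CCN2CCN(c3cccc4c3OCCO4)CC2)c2ccccc2CCC1`, gives 5.02 mg/kg;
compound 2, `c1ccc2c(c1)CC(CCCN1CCN(c3cccc4c3OCCO4)CC1)C2`, gives 0.47 mg/kg;
compound 3, `C1=C(CCN2CCN(c3cccc4c3OCCO4)CC2)c2ccccc2C1`, gives 0.45 mg/kg.

In this assay compound 3 and compound 2 give numbers that lie within the usual scatter of each other, while compound 1 gives a number beyond that scatter from compound 3. The next compound, compound 4, `c1ccc2c(c1)CC(CCN1CCN(c3cccc4c3OCCO4)CC1)C2`, differs from compound 3 in one place: a group of 9 heavy atoms (9 carbon; one five-membered non-aromatic ring of carbon only, one six-membered aromatic ring of carbon only) in place of a group of 9 heavy atoms (9 carbon; one five-membered non-aromatic ring of carbon only, one six-membered aromatic ring of carbon only), on a saturated chain carbon, two bonds along the chain from an amine nitrogen in a ring. Compound 2 carries the same 2,3-dihydro-1H-inden-2-yl group on a longer chain and its number sits close to that of compound 3, so no step beyond the scatter is expected here. The step of a 1.1-fold higher number from compound 3 to compound 4 (0.05 log units; within the scatter) is expected to stay small. Compound 4 is therefore estimated at about 0.5 mg/kg, between 0.2 mg/kg and 1.5 mg/kg.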

Compound 4, dose for 50% inhibition: 0.27 mg/kg
Compound 4: the middle estimate sits 1.9-fold (0.27 log units) above what was measured; measured number inside the range.
By their numbers in this assay, from the lowest: compounds 4, 3 and 2 (each within the scatter of the next); then compound 1.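

Going by these compounds alone, this is the first pair here that differs in one place: in this assay, replacing the group with a double bond outside aromatic rings by 2,3-dihydro-1H-inden-2-yl gives a 1.7-fold lower number from compound 3 to compound 4 (0.22 log units; within the scatter) and so shows that this position tolerates losing that double bond. Nothing available explains why the dose stays so close.

Going by these compounds, how a hydroxyl or methoxy group on the five-membered ring of 2,3-dihydro-1H-inden-2-yl would shift the dose remains open. So does whether a ring containing nitrogen would be accepted at this position.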